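The compounds below may be only part of what the source reports. "The series", "measured", "known", "first", "only" and "open" are said of these compounds alone.

Of the compounds shown here, two with a shared core have been measured so far. Compound 1 `C[C@H](c1ccc(F)cc1)N(Cc1cccc(C(=O)O)c1)C(=O)c1cc2ccccc2s1` carries an aromatic bicyclic amide and in an assay on CHO T-rex cells for antagonist activity at transient receptor potential cation channel subfamily M member 8 (Homo sapiens), read by calcium flux, with a stated time of 20 min (a lower number here means a stronger inhibitor, a higher number a weaker inhibitor), compound 1 gives 145 nM. Compound 2 `CC(c1ccc(F)cc1)N(Cc1cccc(C(=O)O)c1)C(=O)c1ccc2c(c1)CCO2` carries a partly saturated bicyclic amide instead, and in this assay compound 2 gives 3620 nM, the highest of the two numbers and therefore the weaker inhibitor of the pair; the gap between compound 1 and compound 2 is well beyond the usual scatter.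

Compound 3 `CC(c1ccc(F)cc1)N(Cc1cccc(C(=O)O)c1)C(=O)C1Cc2ccccc2C1` differs from compound 2 in one place: a group of 9 heavy atoms (9 carbon; one five-membered non-aromatic ring of carbon only, one six-membered aromatic ring of carbon only) in place of a group of 9 heavy atoms (8 carbon, 1 oxygen; one five-membered non-aromatic ring with 1 hetero atom, one six-membered aromatic ring of carbon only), on a carbonyl carbon. Going by the values given here, no pair of measured compounds shows a step of this kind, so there is no direct guide to its size or direction. The expectation is for compound 3 to land close to compound 2, with a step from compound 2 to compound 3 of a 1.1-fold higher number from compound 2 to compound 3 (0.04 log units; within the scatter) in this assay. Compound 3 is therefore estimated at 4000 nM, within a range from 1000 nM to 15000 nM.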

Compound 3, half-maximal inhibitory concentration: > 5000 nM
Compound 3 was reported as a limit; the forecaster's own chance of this, stated with the estimate: 15%; middle value at least 1.2-fold (0.09 log units) away from the limit.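

Replacing the oxygen-bearing group on the carbonyl carbon with 2,3-dihydro-1H-inden-2-yl, a group of the same heavy-atom count but with no hydrogen-bond acceptor, gives an at least 1.3-fold higher number from compound 2 to compound 3 (0.14 log units; that floor lies within the scatter) in this assay. This is the first change shown at this position, and the all-carbon group brings no gain in inhibition over the group it replaces, though the size of any loss cannot be read. Compound 3 is reported only as a limit, not as a number: the limit of > 5000 nM in this assay, at which 1 of the 3 values shown sits.

Going by these compounds, how far compound 3 truly lies from compound 2 therefore stays open. Also open, on these data alone, is how a different group on this carbonyl carbon, such as an amine-bearing ring or a longer carbon chain, would behave in this assay.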